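Isopropyl to propyl on a carbonyl carbon

A few compounds are considered here, and "the series" means these few. Any claim that something is new, unique, unknown or untested is made for them only; others in the source may bear on it.

Of the compounds shown here, three sharing one core have been measured in a functional assay on A549 cells (Homo sapiens) for antiproliferative activity, read by MTT assay, with a stated time of 48 h; a lower number here means a stronger inhibitor, a higher number a weaker inhibitor. Compound 3 `CC(C)=CCC[C@]1(C)/C=C/[C@@H](OC(=O)C(C)C)[C@](C)(O)/C=C/C(=O)/C(CO)=C\C1` gives 10800 nM, and compound 2 `CC(=O)O[C@@H]1/C=C/[C@@](C)(CCC=C(C)C)C/C=C(/CO)C(=O)/C=C/[C@@]1(C)O` gives 8670 nM, so the two sit level within the usual scatter. Compound 1 `CC[Si](CC)(CC)C/C1=C/C[C@](C)(CCC=C(C)C)/C=C/[C@@H](OC(=O)C=C(C)C)[C@](C)(O)/C=C/C1=O` gives 3100 nM, a lower number than either and so a stronger result, though it differs from compound 3 in more than one place and says little about a single swap.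

The open question is compound 4 `CCCC(=O)O[C@@H]1/C=C/[C@@](C)(CCC=C(C)C)C/C=C(/CO)C(=O)/C=C/[C@@]1(C)O`, which has the same atoms as compound 3, joined differently: propyl in place of isopropyl on a carbonyl carbon. In words, this is propyl in place of isopropyl on a carbonyl carbon.

Among the measured compounds shown here, only one measured step changes the group at this kind of site. Putting isopropyl in place of methyl on a carbonyl carbon gave a 1.2-fold higher number from compound 2 to compound 3 (0.10 log units; within the scatter). That swap is a larger change in the group than the one now in question, yet the number in this assay did not move beyond the scatter. For the measured compounds named here, no measured compound carries a propyl group there, so this reasoning is indirect.

The expected result is a 1.1-fold lower number from compound 3 to compound 4 (0.06 log units; within the scatter), which means no real shift in either direction. The estimate for compound 4 is 9500 nM, with an expected range from 5000 nM to 18000 nM.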

Compound 4, half-maximal inhibitory concentration: 4100 nM
Estimate against measurement, compound 4: 2.3-fold (0.36 log units) above, outside the stated range (below it).
By their numbers in this assay, from the lowest: compounds 1 and 4 (each within the scatter of the next); then compounds 2 and 3 (each within the scatter of the next).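

In this assay the group on this carbonyl carbon turns out to matter, and not only through its size: with propyl in place of isopropyl there is a 2.6-fold lower number from compound 3 to compound 4 (0.42 log units; beyond the scatter), although both groups hold the same three carbons, joined differently. The unbranched group also stands apart from the smaller group of compound 2, with a 2.1-fold lower number from compound 2 to compound 4 (0.33 log units; beyond the scatter), whereas the earlier step, a 1.2-fold higher number from compound 2 to compound 3 (0.10 log units; within the scatter), stayed within the scatter, so among these three compounds a larger group shifted the number only in its unbranched form. Nothing shown here offers a reason for this difference between the branched and unbranched groups.

As far as these compounds go, it remains open whether the trend continues with a longer unbranched chain such as butyl or pentyl, and how this site responds to a phenyl ring, an amine or a carboxylic acid at the end of the group. From the compounds shown here alone, each change here is also read from a single step in one cell line, so it is unknown whether the same order would hold in other cells.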